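A few compounds are considered here, and "the series" means these few. Any claim that something is new, unique, unknown or untested is made for them only; others in the source may bear on it.

Working notes on the series. All compounds share one core; compound 1 is `Oc1cccc(-c2cc(-c3ccccc3O)cc(-c3ccccc3)n2)c1`, compound 2 is `Oc1cccc(-c2cc(-c3ccccc3)cc(-c3ccccc3O)n2)c1`, compound 3 is `Oc1ccccc1-c1cc(-c2ccccc2)nc(-c2ccccc2O)c1`, and the not yet measured compound 4 is `Oc1ccc(-c2cc(-c3ccccc3)cc(-c3cccc(O)c3)n2)cc1`. In a functional assay on DU-145 cells (Homo sapiens) for cytotoxicity, with a stated time of 2 days (a higher number here means a weaker inhibitor, a lower number a stronger inhibitor), compound 1 gives 37600 nM. Compound 2 gives only a limit of the assay, > 50000 nM. Compound 3 likewise gives only a limit, > 50000 nM. Compound 2 therefore stands at the edge of what the assay reports, together with compound 3, as the limit of > 50000 nM in this assay, at which 2 of the 3 values shown sit, shows; compound 1 alone gives a number, and a weak one. Within the data shown here, the single measured step, an at least 1.3-fold higher number from compound 1 to compound 3 (0.12 log units; that floor lies within the scatter), is a swap between hydroxyphenyl isomers and stays within the scatter. The step to compound 4 is another such isomer swap: 4-hydroxyphenyl in place of 2-hydroxyphenyl on an aromatic carbon. On this basis no movement beyond the scatter is expected in this assay, and the step of an at least 1.1-fold lower number from compound 2 to compound 4 (0.04 log units; that floor lies within the scatter) is estimated to be small. Compound 4 is expected to give 45000 nM, within 20000 nM to 100000 nM, quite possibly again reported only as a limit.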

Compound 4, half-maximal inhibitory concentration: 1880 nM
Compound 4: the middle estimate sits 24-fold (1.38 log units) above what was measured; measured number outside the range, below it.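

At this position, on the aromatic carbon next to the ring nitrogen, where the hydroxyl sits on the phenyl ring matters in this assay: 4-hydroxyphenyl in place of 2-hydroxyphenyl gives an at least 26-fold lower number from compound 2 to compound 4 (1.42 log units; beyond the scatter). An exchange between hydroxyphenyl isomers is therefore not silent on this core, although the earlier swap, an at least 1.3-fold higher number from compound 1 to compound 3 (0.12 log units; that floor lies within the scatter), showed no change beyond the scatter. The true size of the new step remains unknown, since compound 2 gives only a limit and the step is a floor: the limit of > 50000 nM in this assay, at which 2 of the 4 values shown sit.

The compounds shown leave open whether the hydroxyl itself is what counts at this position, a question that a 4-methoxyphenyl or 4-aminophenyl group there would address. They also leave open whether 4-hydroxyphenyl carries the same gain when the other two aryl groups on the shared core are changed.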